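The compounds below may be only part of what the source reports. "The series", "measured", "known", "first", "only" and "open" are said of these compounds alone.

The series shares one core, on which a single substituent on an aromatic carbon is varied. Compound 1, `OC[C@H]1OC(n2cnc3c(Nc4ccccc4)nccc32)[C@H](O)[C@@H]1O`, carries an anilino group there, and in a functional assay on EL4 cells (Mus musculus) for inhibition, tested at 100 uM (a higher number here means more inhibition at the concentration tested (going by the name of the read-out), a lower number less inhibition), compound 1 gives 10%. Compound 2, `OC[C@H]1OC(n2cnc3c(S)nccc32)[C@H](O)[C@@H]1O`, carries a sulfanyl group in its place. In this assay compound 2 gives only a limit, < 5%, not a number. The step of a number at least 5 percentage points lower from compound 1 to compound 2 (that floor lies within the scatter) therefore rests on that limit, as shown by the limit of < 5% in this assay, at which 1 of the 2 values shown sits. Compound 2 stands at the lower edge of the numbers shown, with no number of its own.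

Compound 3, `OC[C@H]1OC(n2cnc3c(SCc4ccccc4)nccc32)[C@H](O)[C@@H]1O`, differs from compound 2 by benzyl in place of hydrogen on a sulfur. For the measured compounds named here, the single measured step bears on it only indirectly: going from anilino to sulfanyl removed an aromatic ring and the read-out fell to the limit. Bringing a ring back through the benzyl group is expected to move the read-out of compound 3 toward the level of compound 1, 10%, without clearly clearing the scatter. For compound 3 the step of a number at least 5 percentage points higher from compound 2 to compound 3 (that floor lies within the scatter) is expected. The estimate for compound 3 in this assay is 10%, between 0% and 25%.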

Compound 3, a percentage reported as inhibition, at one concentration (the size of the read-out at that concentration, not a potency): 30%
The estimate for compound 3 lay 20 percentage points below the measured number; measured number outside the range, above it.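

In this assay, placing a benzyl group on the sulfur gives a number at least 25 percentage points higher from compound 2 to compound 3 (beyond the scatter), so this position responds to a change on the sulfur by more than the scatter. Compound 1 and compound 3 each carry a six-membered aromatic ring of carbon only in their substituents, yet the change from anilino to benzylsulfanyl gives a number 20 percentage points higher from compound 1 to compound 3 (beyond the scatter), so the presence of that ring does not alone fix the read-out in these compounds. The rise from the sulfanyl compound is a floor and not a measured size, since compound 2 has only a limit: the limit of < 5% in this assay, at which 1 of the 3 values shown sits.

The compounds shown leave open whether the rise requires the aromatic ring or would also follow from a methyl group or a longer alkyl chain on the sulfur. They also leave open whether the sulfur itself matters, which benzyloxy or benzylamino in place of benzylsulfanyl would test, and whether a substituent on the phenyl ring of the benzyl group, such as a chlorine or a methoxy group, would shift the read-out further.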